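The compounds below may be only part of what the source reports. "The series", "measured", "known", "first", "only" and "open" are said of these compounds alone.

Measured compounds in an ADME assay on HEK293 cells (Homo sapiens) for cytotoxicity, read by resazurin assay, with a stated time of 48 h; a higher number here means that more compound is tolerated, a lower number that less compound is tolerated:
- compound 2, `Cc1ccc(S(=O)(=O)Nc2ccc(-c3nc4ccccc4o3)cc2)cc1`: 88000 nM
- compound 3, `COc1ccc(S(=O)(=O)Nc2ccc3oc(-c4ccccc4)nc3c2)cc1`: 91000 nM
- compound 1, `O=S(=O)(Nc1ccc2oc(-c3ccccc3)nc2c1)c1cccc(C(F)(F)F)c1`: > 100000 nM, which is a limit of the assay and not a number

In this assay compound 2 and compound 3 give numbers that lie within the scatter of each other, so neither can be set above the other. For compound 1 only a limit is reported, (the limit of > 100000 nM in this assay, at which 1 of the 3 values shown sits), and it gives no number to compare. Among the compounds with values here, no step between two measured compounds that differ in one place is available, so there is no measured guide for the change to compound 4.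

Compound 4, `C=Cc1ccc(S(=O)(=O)Nc2ccc(-c3nc4ccccc4o3)cc2)cc1`, differs from compound 2 by vinyl in place of methyl on an aromatic carbon. Both groups carry no donor and no acceptor and no charge, and the change sits on the same aromatic carbon. In this assay the step from compound 2 to compound 4 is expected to be small, not beyond the scatter, and in no set direction. Compound 4 is estimated at 80000 nM, in the range from 40000 nM to 160000 nM, which means an expected step of a 1.1-fold lower number from compound 2 to compound 4 (0.04 log units; within the scatter).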

Compound 4, half-maximal cytotoxic concentration: > 100000 nM
Compound 4 ended at the assay's limit; the forecaster's own chance of this, stated with the estimate: 30%; middle value at least 1.2-fold (0.09 log units) from the limit.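

Compound 4 gives > 100000 nM, which is a limit of the assay and not a number: the limit of > 100000 nM in this assay, at which 2 of the 4 values shown sit.

Within the data shown here, the change from 4-methylphenyl to 4-vinylphenyl provides the only step that can be read in this assay, an at least 1.1-fold higher number from compound 2 to compound 4 (0.05 log units; that floor lies within the scatter). This gives the position its first measured guide: putting vinyl in place of methyl on this aromatic carbon did not lead to a lower number, although only a floor for the step is known.

From the compounds shown here alone, how large the step really is stays open, as does whether it goes beyond the scatter. The compounds shown also do not tell how an amine, a carboxylic acid or a longer chain on the same aromatic carbon would read in this assay.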